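Working notes: from compound 1 to compound 4

The source may hold more compounds than are shown below. What is called first, only, known or untested is meant among the compounds shown, and "the series" means these compounds.

Measured in a physicochemical assay for pharmacokinetics; on this read-out lower numbers stand for a shorter-lived compound and higher numbers for a longer-lived compound:
- Compound 1 `COc1cccc(CNC(=O)N2C(=O)c3ccccc3S2(=O)=O)c1` gives 0.523 h
- Compound 2 `O=C(NCc1ccccc1F)N1C(=O)c2ccccc2S1(=O)=O` gives 0.598 h
- Compound 3 `O=C(OCc1ccccc1)N1C(=O)c2ccccc2S1(=O)=O` gives < 0.0167 h as a limit of the assay

Compound 1 stands level with compound 2 (a 1.1-fold higher number from compound 1 to compound 2 (0.06 log units; within the scatter)). Only these two compounds give true numbers.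

Compound 4 `O=C(NCc1ccc(Br)cc1)N1C(=O)c2ccccc2S1(=O)=O` has 4-bromophenyl in place of 3-methoxyphenyl on a saturated chain carbon bound to an amide-type nitrogen. Among the compounds with values here, one measured step bears on this place, 2-fluorophenyl in place of 3-methoxyphenyl (a 1.1-fold higher number from compound 1 to compound 2 (0.06 log units; within the scatter)), and it stays within the scatter. No step beyond the scatter is therefore expected in this assay, and no direction is favoured (a 1.1-fold higher number from compound 1 to compound 4 (0.02 log units; within the scatter)). Compound 4 is estimated at 0.55 h (expected range 0.28 h to 1.1 h).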

Compound 4, half-life: 0.187 h
Beside the measured number, compound 4's estimate is 2.9-fold (0.47 log units) above it; the whole stated range lies above it.
By their numbers in this assay, from the lowest: compound 4; then compounds 1 and 2 (each within the scatter of the next). At a limit, below all of these: compound 3.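

In this assay the aryl group on a saturated chain carbon bound to an amide-type nitrogen turns out to be a place that can move the number: 4-bromophenyl gives a 2.8-fold lower number from compound 1 to compound 4 (0.45 log units; beyond the scatter) and also a 3.2-fold lower number from compound 2 to compound 4 (0.50 log units; beyond the scatter), both modest, whereas the earlier change to 2-fluorophenyl stayed within the scatter. The aryl group can therefore shorten the half-life with the shared core unchanged. Nothing measured here gives a cause for this drop.

From the compounds shown here alone, whether a longer chain at this place, or an aryl group carrying an amine or a carboxylic acid, moves the number up or further down stays open.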